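A Chloro Group Added to a Low-Number Binder

The source may hold more compounds than are shown below. What is called first, only, known or untested is meant among the compounds shown, and "the series" means these compounds.

In an assay for binding affinity to dual specificity mitogen-activated protein kinase kinase 4 (Homo sapiens), read by KINOMEscan, tested at 100 nM (on this read-out lower numbers stand for a stronger effect and higher numbers for a weaker effect at the one concentration tested), compound 1 `CCCS(=O)(=O)Nc1ccc(F)c(C(=O)c2n[nH]c3ncc(-c4ccc(N)cc4)cc23)c1F` gives 0.1%. Compound 2 `CCCS(=O)(=O)Nc1ccc(F)c(C(=O)c2n[nH]c3ncc(-c4cccc(N(C)C)c4)cc23)c1F` gives 26% in this assay, and compound 3 `CCCS(=O)(=O)Nc1ccc(F)c(C(=O)c2n[nH]c3ncc(-c4ccc(S(N)(=O)=O)cc4)cc23)c1F` gives 0.25%. Compound 3 thus stands second highest of the three numbers: its nearest neighbour is compound 1, with a number 0.2 percentage points higher from compound 1 to compound 3 (within the scatter), while the step of a number 25.8 percentage points lower from compound 2 to compound 3 (beyond the scatter) lies beyond the scatter. Compound 4 `CCCS(=O)(=O)Nc1ccc(F)c(C(=O)c2n[nH]c3ncc(-c4ccc(S(N)(=O)=O)cc4Cl)cc23)c1F` carries one further change: chloro in place of hydrogen on an aromatic carbon. Among the compounds with values here, no measured step adds a chloro group, so none bears on it directly. The steps that exist swap the whole group hanging off the shared core: a number 0.2 percentage points higher from compound 1 to compound 3 (within the scatter) left the number where it was, and a number 25.9 percentage points higher from compound 1 to compound 2 (beyond the scatter) raised it modestly. A single chlorine atom is a smaller alteration than either of those, so no step beyond the scatter is expected in this assay. Compound 4 is therefore expected to give about 1%, between 0.1% and 10%. The expected step is a number 0.8 percentage points higher from compound 3 to compound 4 (within the scatter).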

Compound 4, a percentage reported as activity, at one concentration (the size of the read-out at that concentration, not a potency): 3.4%
Estimate against measurement, compound 4: 2.4 percentage points below; low and high end bracket the measured number.
By their numbers in this assay, from the lowest: compounds 1, 3 and 4 (each within the scatter of the next); then compound 2.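

Earlier steps swapped the whole group on the shared core, whereas here a single chloro group enters, ortho to a large group and meta to the sulfamoyl group, and in this assay the outcome is a number 3.2 percentage points higher from compound 3 to compound 4 (within the scatter), so this ring position accepts chloro with the number still at the low level. The 2-chloro-4-sulfamoylphenyl group also matches the 4-aminophenyl group within the scatter, a number 3.3 percentage points higher from compound 1 to compound 4 (within the scatter), while it keeps the gap to the 3-(dimethylamino)phenyl group, a number 22.6 percentage points lower from compound 2 to compound 4 (beyond the scatter). Nothing at hand says how the chloro group acts at this position. From the compounds shown here alone, whether a fluoro, methyl or methoxy group would read the same at this position stays open. So does whether chloro would read alike on the 4-aminophenyl group, and a reading at one concentration gives no potency for any of these compounds.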